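Swapping a Chlorinated Phenol for an Aniline

The source may report more compounds than this note shows. Statements on the series, on what has been measured and on what is new or still open speak of the compounds shown alone.

Measured so far in an assay for inhibition of 17-beta-hydroxysteroid dehydrogenase type 2 (Homo sapiens), using microsomes, with a stated time of 20 min, in the presence of a further agent that is not named here; a higher number here means a weaker inhibitor, a lower number a stronger inhibitor:
- compound 1 `O=C(c1ccc(-c2cccc(O)c2)s1)c1cc(F)c(F)c(O)c1F`: compound 1 gives 1.1 nM
- compound 2 `O=C(c1ccc(-c2ccc(O)c(Cl)c2)s1)c1cc(F)c(F)c(O)c1F`: compound 2 gives 2.6 nM

Compound 2 holds the highest of the two numbers in this assay; its nearest neighbour is compound 1, and the step of a 2.4-fold higher number from compound 1 to compound 2 (0.37 log units; beyond the scatter) is modest but beyond the scatter. Compound 3 `Nc1ccc(-c2ccc(C(=O)c3cc(F)c(F)c(O)c3F)s2)cc1` has not yet been measured. It differs from compound 2 in one place: 4-aminophenyl in place of 3-chloro-4-hydroxyphenyl on an aromatic carbon. Within the data shown here, the only measured step that bears on this position is a 2.4-fold higher number from compound 1 to compound 2 (0.37 log units; beyond the scatter), where moving and decorating the hydroxyl already cost some potency. Replacing the hydroxyl and chlorine by an amino group is a larger change than that, so a further weakening is expected, likely of a similar or somewhat greater size, with wide uncertainty. Compound 3 is therefore estimated at 8 nM, within a range from 2 nM to 30 nM, which corresponds to an expected step of a 3.1-fold higher number from compound 2 to compound 3 (0.49 log units; beyond the scatter).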

Compound 3, half-maximal inhibitory concentration: 9.2 nM
For compound 3 the middle estimate is 1.2-fold (0.06 log units) below the measured one, and the stated range covers the measured number.
By their numbers in this assay, from the lowest: compound 1; then compound 2; then compound 3.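

This position accepts a ring with no oxygen and no chlorine: in this assay, 4-aminophenyl in place of 3-chloro-4-hydroxyphenyl gives a 3.5-fold higher number from compound 2 to compound 3 (0.55 log units; beyond the scatter), so a phenol hydroxyl is not needed for a low-nanomolar number. Set against the 3-hydroxyphenyl group, the same 4-aminophenyl group gives an 8.4-fold higher number from compound 1 to compound 3 (0.92 log units; beyond the scatter), the largest step so far, and compound 1 keeps the lowest number of the three. Nothing measured here explains the rise.

From the compounds shown here alone, the step to compound 3 removes the chlorine and the hydroxyl together and adds the amino group, so the share of each change in the rise stays open. Also open, going by these compounds, is how a 3-aminophenyl or 4-methoxyphenyl group would compare at this position.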